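This account rests on a few compounds, and the source may have more. Where it says the series, first, only, none or still open, it means among the compounds named here.

Working notes on the series, all values from a functional assay on HeLa cells (Homo sapiens) for antiproliferative activity, read by MTT assay, with a stated time of 24 h; on this read-out higher numbers stand for weaker inhibition and lower numbers for stronger inhibition. Compound 1 (`c1ccc(CSc2nnc(-c3ccc4c(c3)OCCO4)n2-c2ccccc2)cc1`) gives 32800 nM, and compound 2 (`Clc1cccc(CSc2nnc(-c3ccc4c(c3)OCCO4)n2-c2ccccc2)c1`) gives 15000 nM. Compound 3 (`COc1cccc(CSc2nnc(-c3ccc4c(c3)OCCO4)n2-c2ccccc2)c1`) gives no number, only a limit of the assay, > 100000 nM.

The next step leads to compound 4 (`Fc1ccccc1CSc1nnc(-c2ccc3c(c2)OCCO3)n1-c1ccccc1`): 2-fluorophenyl in place of 3-methoxyphenyl on a saturated chain carbon bound to a sulfur. In words, 2-fluorophenyl in place of 3-methoxyphenyl on a saturated chain carbon bound to a sulfur, so the methoxy goes and a fluoro arrives.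

Within the data shown here, three measured steps bear on this. Methoxy in place of hydrogen gave an at least 3.0-fold higher number from compound 1 to compound 3 (0.48 log units; beyond the scatter). Methoxy in place of chloro gave an at least 6.6-fold higher number from compound 2 to compound 3 (0.82 log units; beyond the scatter). Chloro in place of hydrogen gave a 2.2-fold lower number from compound 1 to compound 2 (0.34 log units; beyond the scatter).

Among the measured compounds shown here, in these three compounds, only the methoxy compound reached the limit, and no measured compound carries a fluoro group, so the chloro step is only a loose guide. Without the methoxy, compound 4 should fall back among the measured numbers, near compound 1 at 32800 nM and compound 2 at 15000 nM.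

A lower number in this assay, beyond the scatter, is therefore expected, and the estimated step is an at least 4.0-fold lower number from compound 3 to compound 4 (0.60 log units; beyond the scatter). For compound 4 the estimate is 25000 nM, with an expected range from 9000 nM to 75000 nM.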

Compound 4, half-maximal inhibitory concentration: 24300 nM
For compound 4 the middle estimate is 1.0-fold (0.01 log units) above the measured one; the range from low to high includes it.
By their numbers in this assay, from the lowest: compounds 2, 4 and 1 (each within the scatter of the next, the first and the last beyond it). At a limit, above all of these: compound 3.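

Replacing 3-methoxyphenyl with 2-fluorophenyl on a saturated chain carbon bound to a sulfur gives an at least 4.1-fold lower number from compound 3 to compound 4 (0.61 log units; beyond the scatter) in this assay, so a substituted phenyl at this place does not in itself bring a compound to the limit. Fluoro in place of hydrogen gives a 1.3-fold lower number from compound 1 to compound 4 (0.13 log units; within the scatter), and 2-fluorophenyl in place of 3-chlorophenyl gives a 1.6-fold higher number from compound 2 to compound 4 (0.21 log units; within the scatter), so compound 4 cannot be told apart from either compound 1 or compound 2, even though those two differ from each other beyond the scatter. Compound 3 remains the only compound at a limit, so its step to compound 4 gives a bound and not a measured size:  the limit of > 100000 nM in this assay, at which 1 of the 4 values shown sits.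

Compound 4 differs from compound 3 in both the substituent and its printed ring position, so the series leaves open how much each contributes, a question that 3-fluorophenyl and 2-methoxyphenyl would bear on. Also open, as far as these compounds go, is whether an amine or a carboxylic acid on the phenyl ring, or a longer chain in place of the saturated chain carbon, would move the number beyond the scatter of compound 2.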